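Acetyl in place of methyl on the aryl urea

This account rests on a few compounds, and the source may have more. Where it says the series, first, only, none or still open, it means among the compounds named here.

Compound 1 `Cc1ccc(NC(=O)N[C@H](C)c2ccccc2)cc1` gives 98% in an ADME assay on the whole organism with Oryza sativa as the target, tested at 1 uM (a higher number here means a weaker effect of the compound at the concentration tested, a lower number a stronger effect), the second highest of the three numbers; compound 2 `Cc1ccc(NC(=O)N[C@@H](C)c2ccccc2)cc1` gives 99% and compound 3 `CC(C)c1ccccc1NC(=O)N[C@@H](C)c1ccccc1` gives 96%, both within the scatter of compound 1. Going by the values given here, the only step between measured compounds, a number 1 percentage points higher from compound 1 to compound 2 (within the scatter), is within the scatter and rests on the fact that compounds 1 and 2 differ only in the configuration as drawn alone, so it does not bear on changing a substituent on the ring. Compound 4 `CC(=O)c1ccc(NC(=O)N[C@H](C)c2ccccc2)cc1` differs from compound 1 by acetyl in place of methyl on an aromatic carbon. Among the compounds with values here, no measured step bears on this change, and a step of no more than the scatter is expected, a number 3 percentage points lower from compound 1 to compound 4 (within the scatter). For compound 4 the value in this assay is estimated at 95%, between 84% and 100%.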

Compound 4, a percentage reported as activity, at one concentration (the size of the read-out at that concentration, not a potency): 93%
Compound 4: middle estimate off by 2 percentage points, on the high side, and the stated range covers the measured number.
By their numbers in this assay, from the lowest: compounds 4, 3, 1 and 2 (each within the scatter of the next).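

Acetyl in place of methyl, para to a large group, is the first substituent change read at this position, and in this assay it gives a number 5 percentage points lower from compound 1 to compound 4 (within the scatter) for this pair. The entering group brings a hydrogen-bond acceptor and a double bond outside the ring, yet the read-out stays within the scatter of compound 1. No available evidence bears on this change.

Going by these compounds, whether an amine, a carboxylic acid or a longer chain at this position would give a step beyond the scatter remains open. Also open, on these data alone, is whether the acetyl compound with the opposite configuration as drawn would read the same.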